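A few compounds are considered here, and "the series" means these few. Any claim that something is new, unique, unknown or untested is made for them only; others in the source may bear on it.

Measured compounds:
compound 1 `CC(C)OC(=O)N1CCC(Oc2ncnc3c2CCN3c2ccc(C#N)cc2F)CC1` — 134%
compound 2 `CC(C)OC(=O)N1CCC(Oc2ncnc3c2CCN3c2ccc(S(C)(=O)=O)cn2)CC1` — 111%
compound 3 `CC(C)OC(=O)N1CCC(Oc2ncnc3c2CCN3c2ccc(C#N)c(F)c2)CC1` — 121%

In a functional assay on CHO-K1 cells with Glucose-dependent insulinotropic receptor (Homo sapiens) as the target, read by a luciferase reporter, with a stated time of 5 h (a higher number here means a larger maximal response, a lower number a smaller maximal response), compound 3 stands second highest of the three numbers: compound 1 lies higher by a number 13 percentage points lower from compound 1 to compound 3 (beyond the scatter), whereas the gap to compound 2, a number 10 percentage points higher from compound 2 to compound 3 (within the scatter), is within the scatter. Compound 4 `Cc1cc(S(C)(=O)=O)ccc1N1CCc2c(OC3CCN(C(=O)OC(C)C)CC3)ncnc21` is not yet measured. Its difference from compound 3 is 2-methyl-4-(methylsulfonyl)phenyl in place of 4-cyano-3-fluorophenyl on a nitrogen on an aromatic ring in a ring. The step that bears on it is the exchange of the cyano-bearing aryl for a methylsulfonyl-bearing one, seen as a number 23 percentage points lower from compound 1 to compound 2 (beyond the scatter), a modest loss. Compound 4 carries a methylsulfonyl group on a carbon-only ring rather than a pyridine, so its number is expected to fall between compound 2 and compound 3, a small downward or flat step of a number 9 percentage points lower from compound 3 to compound 4 (within the scatter). Compound 4 is therefore estimated at 112%, expected between 96% and 128%.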

Compound 4, largest response reached (reported as percent of maximum), in percent of the reference or control that the assay uses: 80%
For compound 4 the middle estimate is 32 percentage points above the measured one; the whole stated range lies above it.
By their numbers in this assay, from the lowest: compound 4; then compounds 2 and 3 (each within the scatter of the next); then compound 1.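

Placing 2-methyl-4-(methylsulfonyl)phenyl on this nitrogen gives a number 41 percentage points lower from compound 3 to compound 4 (beyond the scatter) and a number 54 percentage points lower from compound 1 to compound 4 (beyond the scatter) in this assay, so this position can change the maximal response far more than the earlier exchanges showed. The methylsulfonyl group alone does not fix the level: with a number 31 percentage points lower from compound 2 to compound 4 (beyond the scatter), two methylsulfonyl-bearing groups part beyond the scatter. No available data account for this loss.

As far as these compounds go, whether the loss goes with the added methyl or with the methylsulfonyl on the carbon-only ring remains open. Plain 4-(methylsulfonyl)phenyl and 4-cyano-2-methylphenyl at this position would separate the two.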